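Fluoro in place of a methylpyrazolyl on a shared core

The compounds below may be only part of what the source reports. "The series", "measured", "known", "first", "only" and "open" are said of these compounds alone.

Measured compounds:
compound 1, `COc1ccc(-c2cc3nccc(-c4cc(OC)c(OC)c(OC)c4)n3n2)cc1N` — 88 nM
compound 2, `COc1cc(-c2ccnc3cc(-c4c[nH]c5ccccc45)nn23)cc(OC)c1OC` — 40 nM
compound 3, `COc1cc(-c2ccnc3cc(-c4ccc(-c5cnn(C)c5)cc4)nn23)cc(OC)c1OC` — 1240 nM

In a functional assay on B16-F0 cells (Mus musculus) for inhibition, read by CCK-8 assay, with a stated time of 48 h (a higher number here means a weaker inhibitor, a lower number a stronger inhibitor), compound 3 gives the highest number of the three; compound 1 gives 88 nM and compound 2 gives 40 nM. The unmeasured compound 4, `COc1cc(-c2ccnc3cc(-c4ccc(F)cc4)nn23)cc(OC)c1OC`, differs from compound 3 in one place: fluoro in place of 1-methyl-1H-pyrazol-4-yl on an aromatic carbon. The only measured step, a 2.2-fold lower number from compound 1 to compound 2 (0.34 log units; beyond the scatter), exchanges a different aryl group on the shared core and does not bear on this change, so no precedent for swapping a 1-methyl-1H-pyrazol-4-yl against a fluoro exists among these compounds. Among the compounds with values here, what is known is only that compound 3, carrying the larger group, gives the weakest number, while compounds 1 and 2 with smaller aryl groups give lower numbers. Compound 4 is therefore expected to show a lower number than compound 3, a step estimated as a 3.1-fold lower number from compound 3 to compound 4 (0.49 log units; beyond the scatter). For compound 4 the estimated value in this assay is 400 nM, with an expected range from 100 nM to 1500 nM.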

Compound 4, half-maximal inhibitory concentration: 4540 nM
The estimate for compound 4 lay 11-fold (1.05 log units) below the measured number; measured number above the stated range.
By their numbers in this assay, from the lowest: compound 2; then compound 1; then compound 3; then compound 4.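

In this assay, replacing the 1-methyl-1H-pyrazol-4-yl with fluoro gives a 3.7-fold higher number from compound 3 to compound 4 (0.56 log units; beyond the scatter) and does not lower the number, so at this aromatic carbon the smaller substituent is the poorer of the two. The whole 4-fluorophenyl group also compares badly with the other groups on the shared core, with a 110-fold higher number from compound 2 to compound 4 (2.05 log units; beyond the scatter) in place of 1H-indol-3-yl and a 52-fold higher number from compound 1 to compound 4 (1.71 log units; beyond the scatter) in place of 3-amino-4-methoxyphenyl, both large steps that leave compound 4 with the highest number of the four. Nothing on hand accounts for these differences.

The compounds shown leave open how a carboxylic acid or a nitrile in place of the fluoro would read on the same carbon. They also leave open whether another five-membered aromatic ring there would match the 1-methyl-1H-pyrazol-4-yl.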